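Triazole substituent change on the hydroxy-linked core

The compounds below may be only part of what the source reports. "The series", "measured", "known", "first", "only" and "open" are said of these compounds alone.

Three compounds of this series have been run in a functional assay on HCT-116 cells (Homo sapiens) for antiproliferative activity, read by MTT assay, with a stated time of 72 h (a lower number here means a stronger inhibitor, a higher number a weaker inhibitor), so far. Going by the values given here, compound 1 `CCCCc1cn(C[C@H](O)[C@H]2OC(=O)C(OCc3ccccc3)=C2OCc2ccccc2)nn1` is the only one with a number: in this assay compound 1 gives 10400 nM. The other two values are limits rather than numbers, (the limit of > 100000 nM in this assay, at which 2 of the 3 values shown sit). Compound 2 `O=C1O/C(=C\Cn2cc(-c3cc(C(F)(F)F)cc(C(F)(F)F)c3)nn2)C(OCc2ccccc2)=C1OCc1ccccc1` reaches only a limit in this assay, namely > 100000 nM. Compound 3 `COc1ccc(-c2cn(C/C=C3\OC(=O)C(OCc4ccccc4)=C3OCc3ccccc3)nn2)cc1` likewise returns only a limit in this assay, > 100000 nM. Among the compounds with values here, compounds 2 and 3 differ from compound 1 in more than one place, so no single step between measured compounds can be drawn from them.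

Compound 4 `O=C1O[C@H]([C@@H](O)Cn2cc(-c3cc(F)cc(F)c3)nn2)C(OCc2ccccc2)=C1OCc1ccccc1` keeps the shared core of compound 1 and changes one group: 3,5-difluorophenyl in place of butyl on an aromatic carbon. An aromatic ring on the five-membered ring with three nitrogen is also present in compounds 2 and 3, but those carry a different linker, so their limits cannot be read as the effect of this change alone.

Within the data shown here, no measured step supports a firm direction. The step from compound 1 to compound 4 is expected to be small, a 1.9-fold higher number from compound 1 to compound 4 (0.28 log units; within the scatter), leaning toward weaker. Compound 4 is estimated to give 20000 nM in this assay, within 5000 nM to 100000 nM.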

Compound 4, half-maximal inhibitory concentration: 48200 nM
Compound 4: middle estimate off by 2.4-fold (0.38 log units), on the low side; the range from low to high includes it.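

On the shared core, the aromatic carbon of the five-membered aromatic ring with 3 nitrogen now has one readable step: in this assay, 3,5-difluorophenyl in place of butyl gives a 4.6-fold higher number from compound 1 to compound 4 (0.67 log units; beyond the scatter), a modest move toward weaker inhibition that lies beyond the scatter. The position therefore keeps a measurable number with an aromatic ring in place of a chain, and compound 4 gives 48200 nM rather than a limit. The two compounds with a different linker and an aromatic ring on the same carbon stay limits, not numbers, so they add no size to this change: the limit of > 100000 nM in this assay, at which 2 of the 4 values shown sit.

Going by these compounds alone, the single step does not separate the effect of the aromatic ring from that of its two fluorine atoms, and it rests on one pair, so no trend can be drawn for this position. An unsubstituted phenyl, a longer chain or an amine on the same carbon would show whether the direction seen here holds across other groups on the shared core.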